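Ring change on the cyclopentyl member of the series

A few compounds are considered here, and "the series" means these few. Any claim that something is new, unique, unknown or untested is made for them only; others in the source may bear on it.

Values in a functional assay on MV4-11 cells (Homo sapiens) for antiproliferative activity, read by CellTiter-Glo, with a stated time of 72 h; on this read-out lower numbers stand for stronger inhibition of growth and higher numbers for weaker inhibition of growth:
- compound 1 `COCCN[C@H]1CC[C@H](Nc2cc(-c3csc(NCC4CCOCC4)n3)c(Cl)cn2)CC1`: 170 nM
- compound 2 `COCCN[C@H]1CC[C@H](Nc2cc(-c3csc(SCC4CCOCC4)n3)c(Cl)cn2)CC1`: 340 nM
- compound 3 `COCCN[C@H]1CC[C@H](Nc2cc(-c3csc(NCC4CCCC4)n3)c(Cl)cn2)CC1`: 2160 nM

Of the three, compound 3 has the highest number at 2160 nM. Its gaps to the other two lie beyond the scatter: a 13-fold higher number from compound 1 to compound 3 (1.10 log units; beyond the scatter) and a 6.4-fold higher number from compound 2 to compound 3 (0.80 log units; beyond the scatter).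

The next analogue is compound 4 `COCCN[C@H]1CC[C@H](Nc2cc(-c3csc(NCC4CCCCC4)n3)c(Cl)cn2)CC1`, with cyclohexyl in place of cyclopentyl on a saturated chain carbon bound to a nitrogen on an aromatic ring. Going by the values given here, no measured step exchanges one carbon-only ring for another. The closest evidence is the large 13-fold higher number from compound 1 to compound 3 (1.10 log units; beyond the scatter), which shows that a ring change at this place can shift the number. The step of a 2.0-fold higher number from compound 1 to compound 2 (0.30 log units; within the scatter) leaves the ring untouched and says little here. Compound 4 keeps a ring of carbon only, as compound 3 does, so a value near 2160 nM is expected. The expected step, a 1.2-fold lower number from compound 3 to compound 4 (0.08 log units; within the scatter), is small and within the scatter, and its direction is uncertain. For compound 4 the estimated value is 1800 nM, with an expected range of 700 nM to 4500 nM.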

Compound 4, concentration for 50% growth inhibition: 820 nM
For compound 4 the middle estimate is 2.2-fold (0.34 log units) above the measured one; the measured number falls inside the stated range.
By their numbers in this assay, from the lowest: compounds 1 and 2 (each within the scatter of the next); then compound 4; then compound 3.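

In this assay, going by these compounds alone, a carbon-only ring at this place is not a fixed quantity: a 2.6-fold lower number from compound 3 to compound 4 (0.42 log units; beyond the scatter), so the cyclohexyl for cyclopentyl exchange alone moves the number beyond the scatter, which no earlier pair could show. The oxan-4-yl ring keeps its lead over the cyclohexyl ring, with a 4.8-fold higher number from compound 1 to compound 4 (0.68 log units; beyond the scatter), and a 2.4-fold higher number from compound 2 to compound 4 (0.38 log units; beyond the scatter) is also beyond the scatter, although that pair changes both the linking atom and the ring and so separates neither. No evidence in hand bears on these steps. Open, as far as these compounds go, is whether cycloheptyl continues the change seen from cyclopentyl to cyclohexyl, or whether an open chain such as hexyl behaves like the carbon rings. Also open, from the compounds shown here alone, is how piperidin-4-yl, with a ring amine in place of the oxygen of oxan-4-yl, compares with compound 1.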